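From Methoxy to Methyl on the Pyrazole Ring

A few compounds are considered here, and "the series" means these few. Any claim that something is new, unique, unknown or untested is made for them only; others in the source may bear on it.

In an ADME assay on microsomes from liver (Homo sapiens) for metabolic stability (on this read-out higher numbers stand for fast clearance and lower numbers for slow clearance), compound 1 `CCCC(Oc1ccc(-n2cc(OC)cn2)cc1)c1ccc(C(=O)NCCC(=O)O)cc1` gives < 8 mL/min/kg as its reading, which is a limit of the assay and not a number. Compound 2 `O=C(O)CCNC(=O)c1ccc(C(Oc2ccc(-n3cc(C(F)(F)F)cn3)cc2)C2CCC2)cc1` reads 26 mL/min/kg in this assay and differs from compound 1 in more than one place. Compound 3 `CCCC(Oc1ccc(-n2cc(C)cn2)cc1)c1ccc(C(=O)NCCC(=O)O)cc1` keeps the core of compound 1 but has methyl in place of methoxy on an aromatic carbon and is not yet measured. The expected step of an at least 1.1-fold higher number from compound 1 to compound 3 (0.05 log units; that floor lies within the scatter) in this assay is none beyond the scatter. Compound 3 is estimated at 9 mL/min/kg with an expected range from 5 mL/min/kg to 18 mL/min/kg for this reading.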

Compound 3, clearance: 16 mL/min/kg
Compound 3: the middle estimate sits 1.8-fold (0.25 log units) below what was measured; the range from low to high includes it.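

Methyl in place of methoxy on this aromatic carbon of the five-membered ring gives, in this assay, an at least 2.0-fold higher number from compound 1 to compound 3 (0.30 log units; that floor lies within the scatter). For the compounds shown here, this is the first comparison at this position between compounds that differ in one place, which compound 1 and compound 2 could not give. The reading of compound 1 is a limit of the assay, and the step is therefore only a floor: the limit of < 8 mL/min/kg in this assay, at which 1 of the 3 values shown sits.

As far as these compounds go, how a nitrile or chlorine on this carbon would read stays open. So does the reading of trifluoromethyl there on the core of compound 1.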